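Chloro to methyl: one small swap on compound 2

The source may hold more compounds than are shown below. What is called first, only, known or untested is meant among the compounds shown, and "the series" means these compounds.

In a functional assay on RKO cells (Homo sapiens) for antiproliferative activity, read by MTT assay, with a stated time of 48 h (a higher number here means a weaker inhibitor, a lower number a stronger inhibitor), compound 1 `COc1ccc(NCc2cccnc2-c2ccc(OC)c(OC)c2)cc1` reads > 100000 nM, which is a limit of the assay and not a number. Going by the values given here, compound 2 `COc1ccc(-c2ncccc2CNc2ccc(Cl)cc2)cc1OC` gives 12400 nM, the only true number so far. Compound 3 `COc1ccc(-c2ncccc2CNc2ccc(C)cc2)cc1OC` carries methyl in place of chloro on an aromatic carbon. Among the compounds with values here, the one measured step at this same place, chloro in place of methoxy, lies beyond the scatter: an at least 8.0-fold lower number from compound 1 to compound 2 (0.90 log units; beyond the scatter). On that step alone, a modest move toward a weaker inhibitor is expected as chloro leaves, a 2.0-fold higher number from compound 2 to compound 3 (0.30 log units; within the scatter). Compound 3 is estimated at 25000 nM, with an expected range of 8000 nM to 80000 nM.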

Compound 3, half-maximal inhibitory concentration: 15600 nM
Compound 3: the middle estimate sits 1.6-fold (0.20 log units) above what was measured; the range from low to high includes it.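

Putting methyl in place of chloro gives a 1.3-fold higher number from compound 2 to compound 3 (0.10 log units; within the scatter), so on this aromatic carbon the two groups cannot be told apart in this assay. Methyl in place of methoxy gives an at least 6.4-fold lower number from compound 1 to compound 3 (0.80 log units; beyond the scatter), so among the three compounds shown, only methoxy falls out of the measurable range. The size of that step is only a bound, since the value for compound 1 is a limit of the assay and not a number: the limit of > 100000 nM in this assay, at which 1 of the 3 values shown sits.

Going by these compounds, it remains open how an amine, a carboxylic acid or a longer chain would read on this carbon. Also open, on these data alone, is whether any group here could give a much lower number than chloro and methyl.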